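A few compounds are considered here, and "the series" means these few. Any claim that something is new, unique, unknown or untested is made for them only; others in the source may bear on it.

Measured in a functional assay on KYSE-450 cells (Homo sapiens) for inhibition, read by MTT assay, with a stated time of 48 h; a lower number here means a stronger inhibitor, a higher number a weaker inhibitor:
- compound 1 `C/C=C/C(=O)N(Cc1ccc(OC)c([N+](=O)[O-])c1)c1cc(OC)c(OC)c(OC)c1`: 510 nM
- compound 2 `COc1ccc(CNc2cc(OC)c(OC)c(OC)c2)cc1[N+](=O)[O-]`: 16800 nM

Compound 2, at 16800 nM, has the higher number of the two and is the weaker inhibitor in this assay. Compound 3 `COc1ccc(CNc2cc(OC)c(OC)c(OC)c2)cc1Cl` differs from it by chloro in place of nitro on an aromatic carbon. Among the measured compounds shown here, the only measured step, a 33-fold higher number from compound 1 to compound 2 (1.52 log units; beyond the scatter), is large, but it concerns the group on the nitrogen, so it offers no guide to this swap. No step beyond the scatter is therefore expected, in either direction: the estimated change is a 1.2-fold lower number from compound 2 to compound 3 (0.08 log units; within the scatter). The expected value for compound 3 is 14000 nM, within an estimated range of 4000 nM to 40000 nM.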

Compound 3, half-maximal inhibitory concentration: 47800 nM
Compound 3: middle estimate off by 3.4-fold (0.53 log units), on the low side; measured number outside the range, above it.
By their numbers in this assay, from the lowest: compound 1; then compound 2; then compound 3.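

Chloro in place of nitro, ortho to a methoxy group, gives a 2.8-fold higher number from compound 2 to compound 3 (0.45 log units; beyond the scatter) in this assay. This aromatic position therefore responds to the group it carries, even in compounds lacking the (prop-1-en-1-yl)carbonyl group on the nitrogen, and nitro gives the stronger inhibitor of this pair. No measurement available here bears on what lies behind this change.

An amine or a carboxylic acid at this position remains untested among the compounds shown. Also open, from the compounds shown here alone, is whether the same swap would have a similar effect with the (prop-1-en-1-yl)carbonyl group present, as in compound 1.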